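The compounds below may be only part of what the source reports. "The series", "measured", "known", "first", "only" and "open" are said of these compounds alone.

In an ADME assay on Vero cells (Chlorocebus sabaeus) for cytotoxicity, with a stated time of 5 days (a higher number here means a weaker inhibitor, a lower number a stronger inhibitor), compound 1, `CC(C)(CO)Nc1nc(N)nc2c1ncn2[C@H]1C[C@H](N=[N+]=[N-])[C@@H](CO)O1`, gives > 100000 nM, which is a limit and not an exact number. Compound 2, `CNc1nc(Cl)nc2c1ncn2[C@H]1C[C@H](N=[N+]=[N-])[C@@H](CO)O1`, gives > 100000 nM, also a limit. Compound 3, `COc1nc(OC)c2ncn([C@H]3C[C@H](N=[N+]=[N-])[C@@H](CO)O3)c2n1`, gives > 100000 nM, again a limit. Compound 1 therefore has no exact position among these compounds and shares the same limit with the other two.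

Compound 4, `[N-]=[N+]=N[C@H]1C[C@H](n2cnc3c(NC4CC4)nc(N)nc32)O[C@@H]1CO`, keeps the core of compound 1 and changes one group: cyclopropyl in place of 1-(hydroxymethyl)-1-methylethyl on a nitrogen on an aromatic ring. Cyclopropyl stands in place of 1-(hydroxymethyl)-1-methylethyl on a nitrogen on an aromatic ring, so (1-(hydroxymethyl)-1-methylethyl)amino becomes cyclopropylamino.

Within the data shown here, no pair of measured compounds differs in only one place, so the data offer no direct measure of what a single swap does in this assay. The expected result is still little or no movement, and this expectation rests on (the limit of > 100000 nM in this assay, at which 3 of the 3 values shown sit), a result shared by compound 1, compound 2 and compound 3 despite their different groups. The estimated step of a number no higher from compound 1 to compound 4 (the limit leaves the size open) is none beyond the scatter, and any real shift is expected to lean towards a lower number, meaning a stronger inhibitor. For compound 4 the estimated value is 100000 nM, with an expected range from 30000 nM to 100000 nM.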

Compound 4, half-maximal inhibitory concentration: > 100000 nM
Compound 4 gave a limit, no number (the forecaster's own chance of this, stated with the estimate: 75%); the middle value lies on the limit itself.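

In this assay compound 4 gives > 100000 nM as a limit and not a number. Compound 1 also gives a limit, so no step can be read between compound 1 and compound 4. How far any of these compounds lies from that limit stays open, and with it whether swapping these groups changes anything, since all share one result: the limit of > 100000 nM in this assay, at which 4 of the 4 values shown sit.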